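Swapping Bromine for Fluorine on an Inactive Pair

This account rests on a few compounds, and the source may have more. Where it says the series, first, only, none or still open, it means among the compounds named here.

Compound 2, `CCOC(=O)C1=Cc2ccccc2OC1(OCc1cc(-c2ccc(Br)cc2)no1)C(F)(F)F`, was tested in a functional assay on MCF7 cells (Homo sapiens) for inhibition, read by MTT assay, with a stated time of 24 h; a lower number here means a stronger inhibitor, a higher number a weaker inhibitor. There compound 2 gives > 150000 nM, which is a limit of the assay and not a number. Its closest relative, compound 1, `CCOC(=O)C1=Cc2ccccc2OC1(OCc1cc(-c2ccc(C)cc2)no1)C(F)(F)F`, differs from it only by carrying a methyl where compound 2 carries a bromo. Compound 1 gives > 150000 nM, again a limit and not a number. The step that the two limits leave unreadable from compound 1 to compound 2 therefore cannot be read, because both of its ends sit at the limit of > 150000 nM in this assay, at which 2 of the 2 values shown sit. Compound 2 thus stands at the ceiling of what this assay can report, with no number to set it against.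

Compound 3, `CCOC(=O)C1=Cc2ccccc2OC1(OCc1cc(-c2ccc(F)cc2)no1)C(F)(F)F`, is the next variation: fluoro in place of bromo on an aromatic carbon. Within the data shown here, the only measured step on this core, the one from compound 1 to compound 2, has no readable size, so it gives no direction or magnitude for the new change; what it does show is that two different groups on that aromatic carbon both left the compound outside the measurable range. Compound 3 is therefore expected to follow the same course, with an estimated step that the limit leaves unreadable from compound 2 to compound 3 that stays within the scatter. The estimate for compound 3 in this assay is 200000 nM, in the range 60000 nM to 700000 nM, most likely reported again as a limit.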

Compound 3, half-maximal inhibitory concentration: 48200 nM
For compound 3 the middle estimate is 4.1-fold (0.62 log units) above the measured one, outside the stated range (below it).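

Compound 3 brings this series inside the measurable range of this assay, which shows that this aromatic carbon, para to a large group, is a place where a change of group can alter the read-out, something compound 1 and compound 2 could not show. The 4-bromophenyl to 4-fluorophenyl change gives an at least 3.1-fold lower number from compound 2 to compound 3 (0.49 log units; beyond the scatter), and fluoro in place of methyl gives an at least 3.1-fold lower number from compound 1 to compound 3 (0.49 log units; beyond the scatter). Both sizes are minimums and not exact values, because each step starts from a compound that has no number of its own: the limit of > 150000 nM in this assay, at which 2 of the 3 values shown sit.

On these data alone, the step between compound 1 and compound 2 remains unreadable, so it stays open whether methyl and bromo differ from each other at all, and a single measured compound cannot show how far fluoro stands apart from other groups. As far as these compounds go, whether chloro, an amine or a carboxylic acid on this same carbon would lower the number further, or leave it out of range again, also stays open.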